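This account rests on a few compounds, and the source may have more. Where it says the series, first, only, none or still open, it means among the compounds named here.

Measured compounds:
Compound 1 `Cc1nnsc1CO/N=C/c1c(C)nn(C)c1Oc1cccc(F)c1` — in a functional assay on PANC-1 cells (Homo sapiens) for inhibition, read by MTT assay, with a stated time of 48 h (on this read-out lower numbers stand for stronger inhibition and higher numbers for weaker inhibition), compound 1 gives > 50000 nM, a limit of the assay.
Compound 2 `Cc1nnsc1CO/N=C/c1c(C)nn(C)c1Oc1ccc(Br)cc1` — in this assay compound 2 gives 12800 nM.
Compound 3 `Cc1cccc(Oc2c(/C=N/OCc3snnc3C)c(C)nn2C)c1` — in this assay compound 3 gives > 50000 nM, a limit of the assay.

Compound 3 stands at a limit, with no number of its own; the limit of > 50000 nM in this assay, at which 2 of the 3 values shown sit, covers it together with compound 1. For the measured compounds named here, the only number in the set belongs to compound 2, and the step of an at least 3.9-fold higher number from compound 2 to compound 3 (0.59 log units; beyond the scatter) is readable in one direction only. Likewise an at least 3.9-fold lower number from compound 1 to compound 2 (0.59 log units; beyond the scatter) is readable as a floor, while a step that the two limits leave unreadable from compound 1 to compound 3 cannot be sized from two limits.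

Compound 4 `Cc1nnsc1CO/N=C/c1c(C)nn(C)c1Cl` differs from compound 3 by chloro in place of 3-methylphenoxy on an aromatic carbon. Going by the values given here, none of the measured steps bears on this change: each of them swaps one aryl group for another on the oxygen, whereas here the whole 3-methylphenoxy group leaves and a single chlorine enters. The measured steps therefore give no direction for compound 4, only the observation that compound 3 itself sits at the limit. Compound 4 is expected to remain near that limit, with the step of a number no higher from compound 3 to compound 4 (the limit leaves the size open) estimated as none readable beyond the scatter. The estimate for compound 4 in this assay is 50000 nM, within 15000 nM to 150000 nM, most likely reported as a limit again.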

Compound 4, half-maximal inhibitory concentration: 26600 nM
For compound 4 the middle estimate is 1.9-fold (0.27 log units) above the measured one; low and high end bracket the measured number.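

In this assay compound 4 gives 26600 nM, a measured number, so this aromatic carbon keeps a readable result with chloro and no aryl ring on the oxygen, something the swaps of one aryl group for another could not show. For the compounds shown here, the steps of an at least 1.8-fold lower number from compound 3 to compound 4 (0.27 log units; that floor lies within the scatter) and an at least 1.8-fold lower number from compound 1 to compound 4 (0.27 log units; that floor lies within the scatter) are floors only because each starts from a limit of the assay: the limit of > 50000 nM in this assay, at which 2 of the 4 values shown sit. The one step between two numbers, a 2.1-fold higher number from compound 2 to compound 4 (0.32 log units; beyond the scatter), places 4-bromophenoxy ahead of chloro at this carbon, whereas 3-methylphenoxy and 3-fluorophenoxy show no such advantage.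

Open, on these data alone, is how an amine, a methoxy group or a carboxylic acid on this carbon would compare with chloro and with 4-bromophenoxy. Also open, as far as these compounds go, is what a plain phenoxy group would give here, and with it how much of the result of the 4-bromophenoxy group rests on the bromine.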